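Fluoro removal on the pendant phenyl of compound 2

This account rests on a few compounds, and the source may have more. Where it says the series, first, only, none or still open, it means among the compounds named here.

Two members of the series have a number in a functional assay, read by spectrophotometry, with a stated time of 60 min, tested at 100 uM; on this read-out lower numbers stand for a weaker effect and higher numbers for a stronger effect at the one concentration tested. Compound 1 `COc1cc(OC)cc(-n2c(-c3ccccc3)nc(C)c2C)c1` gives 58.6% in this assay, and compound 2 `COc1ccc(-n2c(-c3ccc(F)cc3)nc(C)c2C)cc1` gives 52.9%. For the measured compounds named here, compound 2 stands as the lower of the two numbers, yet its nearest neighbour, compound 1, lies within the scatter of it, so the two values show no difference between these compounds.

Compound 3 `COc1ccc(-n2c(-c3ccccc3)nc(C)c2C)cc1` remains to be measured in this assay. It differs from compound 2 by hydrogen in place of fluoro on an aromatic carbon. Going by the values given here, no step between two measured compounds of this kind exists in the set, so the size of this change can only be judged from the two values at hand. Since compound 2 gives 52.9% and compound 1 gives 58.6% with no gap beyond the scatter, the expected step is small, a number 2.1 percentage points higher from compound 2 to compound 3 (within the scatter), in neither direction beyond the scatter. Compound 3 is expected to give 55% in this assay, within a range from 40% to 70%.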

Compound 3, a percentage reported as activity, at one concentration (the size of the read-out at that concentration, not a potency): 52.9%
The estimate for compound 3 lay 2.1 percentage points above the measured number; measured number inside the range.
By their numbers in this assay, from the lowest: compounds 2, 3 and 1 (each within the scatter of the next).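

In this assay, for the compounds shown here, hydrogen in place of fluoro on the pendant phenyl gives no change at the digits printed from compound 2 to compound 3 (within the scatter) and provides the first one-place comparison. For this single pair, the 4-fluorophenyl to phenyl change leaves the read-out at the one tested concentration without a difference beyond the scatter. Fluoro is therefore not required at this aromatic carbon for the effect seen in compound 2, although a single-concentration read-out gives no measure of potency. No available data explain this outcome.

From the compounds shown here alone, it remains open whether an amine or a carboxylic acid on this aromatic carbon would shift the read-out beyond the scatter. The same question applies to a longer alkyl chain at this carbon, and one pair cannot show whether the result holds with other substituents on the shared core.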